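From compound 2 to compound 3: a side-chain exchange

The compounds below may be only part of what the source reports. "The series", "measured", "known", "first", "only" and "open" are said of these compounds alone.

In an in vitro ADME assay on microsomes from liver (Homo sapiens) for metabolic stability, tested at 5 uM (a higher number here means that the compound lasts longer, a lower number that the compound disappears faster), compound 1 `CC(C)CCn1nc(-c2ccccc2)c(O)c(C2=NS(=O)(=O)c3cc(NS(C)(=O)=O)ccc3N2)c1=O` shows a half-life of 0.633 h as its reading. Compound 2 `COC(C)(C)CCn1nc(-c2cccs2)c(O)c(C2=NS(=O)(=O)c3cc(NS(C)(=O)=O)ccc3N2)c1=O` has > 1 h as its reading, which is a limit of the assay and not a number. Compound 2 is therefore placed only by the limit of > 1 h in this assay, at which 1 of the 2 values shown sits, and by no exact figure. Compound 3 `CS(=O)(=O)Nc1ccc2c(c1)S(=O)(=O)N=C(c1c(O)c(-c3cccs3)nn(CC3(C(F)(F)F)CC3)c1=O)N2` carries 1-(trifluoromethyl)cyclopropyl in place of 2-methoxy-2-methylpropyl on a saturated chain carbon bound to an aromatic nitrogen. Within the data shown here, no measured step bears on this change, so in this assay the expected step that the limit leaves unreadable from compound 2 to compound 3 is none beyond the scatter. Compound 3 is expected at 1.2 h within an estimated range of 0.6 h to 2.5 h overall.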

Compound 3, half-life: > 1 h
Compound 3: a limit, no number; the forecaster's own chance of this, stated with the estimate: 60%; the middle value is on the limit's open side.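

No step from compound 2 to compound 3 can be read in this assay, because both readings are limits and not numbers: the limit of > 1 h in this assay, at which 2 of the 3 values shown sit.

As far as these compounds go, how long either compound lasts past that limit, and whether the side-chain exchange alters the half-life at all, remains open.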